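The source may report more compounds than this note shows. Statements on the series, on what has been measured and on what is new or still open speak of the compounds shown alone.

Compound 1 `COc1cc(NC(=S)Nc2ccccc2)cc(OC)c1OC` was tested in a toxicity assay on RAW264.7 cells (Mus musculus) for cytotoxicity, read by MTT assay, with a stated time of 24 h (on this read-out lower numbers stand for higher toxicity in this test and higher numbers for lower toxicity in this test), where compound 1 gives 154000 nM. Compound 2 `CCCCNC(=S)NCc1ccccc1` gives 177000 nM in this assay; the two numbers lie within the usual scatter of each other, so neither compound can be set apart from the other on this read-out. Compound 3 `COc1cc(NC(=S)NC#N)cc(OC)c1OC` has not yet been measured. It differs from compound 1 in one place: cyano in place of phenyl on an amide-type nitrogen, so that anilino becomes cyanoamino. Going by the values given here, no step between measured compounds exists to guide this change, and no shift beyond the scatter is expected; the expected step is a 1.2-fold higher number from compound 1 to compound 3 (0.07 log units; within the scatter). Compound 3 is estimated to give 180000 nM, within a range from 70000 nM to 450000 nM.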

Compound 3, half-maximal cytotoxic concentration: >= 200000 nM
Compound 3: only a limit was reported; the forecaster's own chance of this, stated with the estimate: 25%; at least 1.1-fold (0.04 log units) between middle value and limit.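

In this assay, compound 3 gives >= 200000 nM, which is a limit of the assay and not a number. Cyano in place of phenyl on this amide-type nitrogen gives an at least 1.2-fold higher number from compound 1 to compound 3 (0.11 log units; that floor lies within the scatter), so losing the aromatic ring here brings no sign of a lower number, the direction of higher toxicity. The full size of the step cannot be read because the measurement ends at a limit: the limit of >= 200000 nM in this assay, at which 1 of the 3 values shown sits.

Going by these compounds, whether an amine or a longer chain on the same nitrogen would behave the same way remains open.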